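Tert-butyl for bromo on the aryl of a hydroxamate

The compounds below may be only part of what the source reports. "The series", "measured", "known", "first", "only" and "open" are said of these compounds alone.

Compound 1 `O=C(CCC1=CCN(CCCc2ccc(Br)cc2)C1=O)NO` is a hydroxamic acid whose side chain carries a bromophenyl group. Going by the values given here, in a functional assay on NUGC-3 cells (Homo sapiens) for inhibition, read by sulforhodamine B assay (a higher number here means a weaker inhibitor of growth, a lower number a stronger inhibitor of growth), compound 1 gives 2200 nM, the lowest of the three numbers measured so far, though its gaps to the other two fall within the usual scatter. Compound 2 `Cc1cccc(CN2CC=C(CCC(=O)NO)C2=O)c1` gives 4280 nM in this assay, and compound 3 `Cc1ccc(CN2CC=C(CCC(=O)NO)C2=O)cc1` gives 4280 nM. Compound 4 `CC(C)(C)c1ccc(CCCN2CC=C(CCC(=O)NO)C2=O)cc1` differs from compound 1 by tert-butyl in place of bromo on an aromatic carbon. Among the compounds with values here, no measured pair shows the effect of such an exchange, so the step is expected to be small, with no clear direction beyond the scatter, as the estimated step of a 1.1-fold lower number from compound 1 to compound 4 (0.04 log units; within the scatter) states. Compound 4 is therefore expected to give about 2000 nM in this assay, within a range from 800 nM to 5000 nM.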

Compound 4, concentration for 50% growth inhibition: 2200 nM
Estimate against measurement, compound 4: 1.1-fold (0.04 log units) below, and the stated range covers the measured number.
By their numbers in this assay, from the lowest: compounds 1, 4, 2 and 3 (each within the scatter of the next).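

The exchange of bromo for tert-butyl, with 4 heavy atoms entering where 1 leaves, gives no change at the digits printed from compound 1 to compound 4 (within the scatter) in this assay and shows that this aromatic carbon, para to a large group, accepts the larger group with no change beyond the scatter. No measurement available here bears on why the number holds. As far as these compounds go, whether an amine or a carboxylic acid on this aromatic carbon would also leave the number unchanged stays open, as does the effect of a longer chain in place of tert-butyl.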